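A few compounds are considered here, and "the series" means these few. Any claim that something is new, unique, unknown or untested is made for them only; others in the source may bear on it.

Working notes on the series. The shared core of compound 1 `Cc1cc(-c2ccc(C#N)cc2)c(Cl)cc1Oc1ccnc(Nc2ccc(C#N)cc2)n1` carries a methyl group and a chloro group on the central ring. In a functional assay on MT4 cells (Homo sapiens) for cytotoxicity, read by MTT assay, with a stated time of 5 days (on this read-out lower numbers stand for higher toxicity in this test and higher numbers for lower toxicity in this test), compound 1 gives > 285000 nM, which is a limit of the test and not a number. Compound 2 `N#Cc1ccc(Nc2nccc(Oc3ccc(-c4ccc(C#N)cc4)c(Cl)c3)n2)cc1` lacks the methyl group, and in this assay compound 2 gives 31100 nM. Within the data shown here, compound 3 `Cc1cc(-c2ccc(C#N)cc2)ccc1Nc1ccnc(Nc2ccc(C#N)cc2)n1` carries the methyl group but no chloro group, and in this assay compound 3 gives 9200 nM; compound 3 also differs from the rest in the linker, and no single step connects it to compound 1.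

Among the measured compounds shown here, the only measured step from compound 1 is an at least 9.1-fold lower number from compound 1 to compound 2 (0.96 log units; beyond the scatter); its size is bounded by the limit of > 285000 nM in this assay, at which 1 of the 3 values shown sits, so only a floor is known.

Compound 4 `Cc1cc(-c2ccc(C#N)cc2)ccc1Oc1ccnc(Nc2ccc(C#N)cc2)n1` is the target: hydrogen in place of chloro on an aromatic carbon. For the measured compounds named here, this change is not the one measured in the step from compound 1 to compound 2, so that step gives direction only loosely; still, the one change measured from compound 1 moved the number down, and compound 3, which also lacks the chloro group, sits at 9200 nM. A drop beyond the scatter is therefore expected in this assay, as an at least 9.5-fold lower number from compound 1 to compound 4 (0.97 log units; beyond the scatter). Compound 4 is estimated at 30000 nM, within 8000 nM to 150000 nM.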

Compound 4, half-maximal cytotoxic concentration: > 310000 nM
Compound 4: only a limit was reported (the forecaster's own chance of this, stated with the estimate: 25%); at least 10-fold (1.01 log units) between middle value and limit.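

In this assay compound 4 gives > 310000 nM as a limit of the test and not a number. Compound 1 also stands at a limit, so the step between compound 1 and compound 4 cannot be read. The compounds shown leave open whether hydrogen in place of chloro on this aromatic carbon changes the number at all, and in which direction.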